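Ethyl ester in place of the free acid: compound 3

This account rests on a few compounds, and the source may have more. Where it says the series, first, only, none or still open, it means among the compounds named here.

Measured so far:
compound 1, `C/C=C/C(=O)Nc1ccc(Cn2nc(-c3ccc(Oc4ccccc4)cc3)cc2C(=O)OCC)cc1`: > 60000 nM
compound 2, `O=C(CCl)Nc1ccc(Cn2nc(-c3ccc(Oc4ccccc4)cc3)cc2C(=O)O)cc1`: 1200 nM

Among the compounds with values here, in a functional assay on Maver1 cells (Homo sapiens) for inhibition, read by luminescence and CellTiter-Glo, with a stated time of 72 h (a higher number here means a weaker inhibitor, a lower number a stronger inhibitor), compound 2 gives 1200 nM, the only number recorded. For compound 1 this assay reports only a limit, (the limit of > 60000 nM in this assay, at which 1 of the 2 values shown sits). Within the data shown here, no step between measured compounds is available, and compound 1 and compound 2 differ in more than one place, so their two values show only that compound 2 returns a number where compound 1 does not.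

Compound 3, `CCOC(=O)c1cc(-c2ccc(Oc3ccccc3)cc2)nn1Cc1ccc(NC(=O)CCl)cc1`, differs from compound 2 by ethyl in place of hydrogen on an oxygen next to a carbonyl group. The expected step from compound 2 to compound 3 in this assay is a moderate loss, a 2.9-fold higher number from compound 2 to compound 3 (0.46 log units; beyond the scatter), beyond the usual scatter but not to the limit. For compound 3 the estimate in this assay is 3500 nM, with a range from 700 nM to 25000 nM.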

Compound 3, half-maximal inhibitory concentration: 400 nM
Estimate against measurement, compound 3: 8.8-fold (0.94 log units) above, outside the stated range (below it).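

In this assay, with chloromethyl on the amide carbonyl carbon, the free acid is not required at this position: ethyl in place of hydrogen on the oxygen gives a 3.0-fold lower number from compound 2 to compound 3 (0.48 log units; beyond the scatter), so the ethyl ester is the stronger of this pair. With the ethyl ester held fixed, the other site can now be read as well: chloromethyl in place of prop-1-en-1-yl on a carbonyl carbon gives an at least 150-fold lower number from compound 1 to compound 3 (2.17 log units; beyond the scatter). Compound 1 stands at a limit of the assay and not at a number, so that step is open-ended: the limit of > 60000 nM in this assay, at which 1 of the 3 values shown sits.

Open, from the compounds shown here alone, is how a methyl ester, an isopropyl ester or a primary amide would read in place of the ethyl ester. Also open, going by these compounds, is whether the carboxylic acid and the ethyl ester keep this order with prop-1-en-1-yl or another group, such as bromomethyl, on the carbonyl carbon.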